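A few compounds are considered here, and "the series" means these few. Any claim that something is new, unique, unknown or untested is made for them only; others in the source may bear on it.

Of the compounds shown here, three share one core and have been tested in a functional assay on HT-29 cells (Homo sapiens) for inhibition, read by MTT assay, with a stated time of 48 h; on this read-out lower numbers stand for stronger inhibition and higher numbers for weaker inhibition. Compound 1, `COc1ccc(-n2c(SC)nnc2-c2cc(OC)c(OC)c(OC)c2)cc1`, gives > 60000 nM, which is a limit of the assay and not a number. Compound 2, `COc1ccc(-n2c(SCC(=O)c3ccc(OC)c(O)c3)nnc2-c2cc(OC)c(OC)c(OC)c2)cc1`, gives > 60000 nM, again a limit. Compound 3, `CCSc1nnc(-c2cc(OC)c(OC)c(OC)c2)n1-c1ccc(N(C)C)cc1`, gives > 60000 nM, likewise a limit. Within the data shown here, the only step between measured compounds, a step that the two limits leave unreadable from compound 1 to compound 2, cannot be read, since both ends sit at the limit; the same holds for compound 3, whose value is a limit like the other two, as the limit of > 60000 nM in this assay, at which 3 of the 3 values shown sit, shows.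

Compound 4, `COc1cc(-c2nnc(SCC(=O)Nc3ccc(Cl)cc3)n2-c2ccc(N(C)C)cc2)cc(OC)c1OC`, differs from compound 3 by (4-chlorophenyl)carbamoyl in place of methyl on a saturated chain carbon bound to a sulfur. Among the measured compounds shown here, no measured step bears on this change with a readable size, so no direction can be drawn from the data; the estimate rests on compound 3 standing at > 60000 nM. Compound 4 is therefore expected to give about 80000 nM, within 15000 nM to 400000 nM. That estimate means an expected step that the limit leaves unreadable from compound 3 to compound 4, most likely again reported only as a limit.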

Compound 4, half-maximal inhibitory concentration: > 60000 nM
Compound 4: only a limit was reported; the forecaster's own chance of this, stated with the estimate: 70%; the middle value lies beyond the limit too.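

No step can be read from compound 3 to compound 4, since both stand only as limits: the limit of > 60000 nM in this assay, at which 4 of the 4 values shown sit.

The compounds shown leave open how any of them truly ranks in this assay, and which change to the shared core, if any, would give a readable value.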